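Solubility Across Three Measured Compounds and a Fourth

The compounds below may be only part of what the source reports. "The series", "measured", "known", "first", "only" and "open" are said of these compounds alone.

Compound 1 `Cc1cc(NC(=O)Nc2ccc(C(=O)O)cc2)c2ccccc2n1` — compound 1 gives 9300 nM
Compound 2 `COC(=O)c1ccc(NC(=O)Nc2cc(C)nc3ccccc23)cc1` — compound 2 gives 1200 nM
Compound 3 `Cc1cc(NC(=O)Nc2ccc(Cl)cc2)c2ccccc2n1` — compound 3 gives 1400 nM

These three compounds were measured in a physicochemical assay for solubility, at pH 7.4; a lower number here means a less soluble compound, a higher number a more soluble compound. Compound 3 has the second highest of the three numbers; its nearest neighbour is compound 2, with a 1.2-fold higher number from compound 2 to compound 3 (0.07 log units; within the scatter), and its furthest is compound 1, with a 6.6-fold lower number from compound 1 to compound 3 (0.82 log units; beyond the scatter). The other measured step, a 7.8-fold lower number from compound 1 to compound 2 (0.89 log units; beyond the scatter), is of similar size to the step from compound 1 to compound 3.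

Compound 4 `Cc1cc(NC(=O)Nc2ccc(C(C)(C)C)cc2)c2ccccc2n1` has not yet been measured in this assay. It differs from compound 3 as follows: tert-butyl in place of chloro on an aromatic carbon. For the measured compounds named here, none of the measured steps exchanges chloro for tert-butyl; the two larger steps both involve loss of carboxy, and the one step that swaps a group at the same place, a 1.2-fold higher number from compound 2 to compound 3 (0.07 log units; within the scatter), is within the scatter. For compound 4 a small downward step is therefore expected, a 2.3-fold lower number from compound 3 to compound 4 (0.37 log units; beyond the scatter), possibly no larger than the scatter. The estimate for compound 4 is 600 nM, expected to lie between 200 nM and 1800 nM.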

Compound 4, solubility: 6200 nM
For compound 4 the middle estimate is 10-fold (1.01 log units) below the measured one, outside the stated range (above it).
By their numbers in this assay, from the lowest: compounds 2 and 3 (each within the scatter of the next); then compounds 4 and 1 (each within the scatter of the next).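

At the position on an aromatic carbon para to a large group, chloro and methoxycarbonyl had given numbers within the scatter of each other, but tert-butyl separates from both in this assay, with a 4.4-fold higher number from compound 3 to compound 4 (0.65 log units; beyond the scatter) and a 5.2-fold higher number from compound 2 to compound 4 (0.71 log units; beyond the scatter) as the two steps beyond the scatter. The carboxy compound no longer stands apart, since a 1.5-fold lower number from compound 1 to compound 4 (0.18 log units; within the scatter) places tert-butyl, with no hydrogen-bond donors, no hydrogen-bond acceptors and no net charge, level with it. Nothing in the data shown bears on the reason for this result.

The compounds shown leave open whether this higher number is particular to tert-butyl or would also appear with an isopropyl, a methyl or an amine at the same position. They also leave open whether tert-butyl would give the same step on a different core.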